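MCF7 antiproliferation notes: amide N-ethylation on the indole carboxamide

This account rests on a few compounds, and the source may have more. Where it says the series, first, only, none or still open, it means among the compounds named here.

Measured so far:
- Compound 1 `CC[C@@H]1C(=O)N(C)c2cnc(-n3ccc4cc(C(N)=O)ccc43)nc2N1C1CCCC1`: 1830 nM
- Compound 2 `CC[C@@H]1C(=O)N(C)c2cnc(Nc3ccc(S(=O)(=O)NC4CCCC4)cc3)nc2N1C1CCCC1`: 688 nM
- Compound 3 `CCC1C(=O)N(C)c2cnc(Nc3ccc(S(N)(=O)=O)cc3)nc2N1c1ccn(C)n1`: 36600 nM

All three were read in a functional assay on MCF7 cells (Homo sapiens) for antiproliferative activity, read by CCK-8 assay, with a stated time of 72 h; on this read-out higher numbers stand for weaker inhibition of growth and lower numbers for stronger inhibition of growth. Compound 1 stands second highest of the three numbers. Its nearest neighbour is compound 2, whose lower number lies beyond the scatter, so compound 2 inhibits growth more strongly than compound 1 on this read-out. Compound 3 is the furthest away, with a number well beyond the scatter above that of compound 1, so compound 3 is the weakest of the three. Among the measured compounds shown here, compounds 2 and 3 differ from compound 1 in more than one place, so no single step between measured compounds is available.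

Compound 4 `CCNC(=O)c1ccc2c(ccn2-c2ncc3c(n2)N(C2CCCC2)[C@H](CC)C(=O)N3C)c1` is the next compound to be run in this assay. It differs from compound 1 only at the carboxamide: ethyl in place of hydrogen on an amide-type nitrogen. Nothing measured here isolates a change on that amide-type nitrogen, so no step size can be read off. The expected step from compound 1 to compound 4 is a 1.1-fold lower number from compound 1 to compound 4 (0.06 log units; within the scatter), with no movement beyond the scatter in either direction expected. For compound 4 the estimate is 1600 nM, within 600 nM to 4500 nM.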

Compound 4, concentration for 50% growth inhibition: 784 nM
Beside the measured number, compound 4's estimate is 2.0-fold (0.31 log units) above it, and the stated range covers the measured number.
By their numbers in this assay, from the lowest: compounds 2 and 4 (each within the scatter of the next); then compound 1; then compound 3.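

In this assay, among the compounds shown here, the carboxamide position gives the first single-place step: ethyl in place of hydrogen on the amide-type nitrogen gives a 2.3-fold lower number from compound 1 to compound 4 (0.37 log units; beyond the scatter) and so a modest gain in growth inhibition. One amide hydrogen can therefore be given up at this position without loss on this read-out, and the position accepts a small alkyl group. Nothing available here gives a reason for the gain.

As far as these compounds go, this rests on one pair, so it remains open whether the gain continues with a longer chain such as propyl, with a cyclopropyl ring, or with a chain ending in an amine. A second methyl or ethyl on the same nitrogen, which would remove the remaining amide hydrogen, is also untested among the compounds shown.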